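Methoxy on the anilino ring of the aminothiazole amides

A few compounds are considered here, and "the series" means these few. Any claim that something is new, unique, unknown or untested is made for them only; others in the source may bear on it.

Measured compounds:
compound 1, `Cc1nc(SCC(=O)Nc2nc(-c3ccc(Cl)cc3)cs2)n(Nc2ccccc2)c1C`: 11600 nM
compound 2, `Cc1ccc(Nn2c(SCC(=O)Nc3nc(-c4ccccc4)cs3)nc(C)c2C)cc1`: > 100000 nM

Among the measured compounds shown here, in a functional assay on A549 cells (Homo sapiens) for antiproliferative activity, read by sulforhodamine B assay, with a stated time of 48 h (a lower number here means a stronger inhibitor of growth, a higher number a weaker inhibitor of growth), compound 1 gives 11600 nM, and this is the only number in hand for the series. For compound 2 the result is a limit only, > 100000 nM, which places it at the limit of > 100000 nM in this assay, at which 1 of the 2 values shown sits. Compound 2 differs from compound 1 in two places at once, so the two results can only be set side by side: one compound with a number, the other with none.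

Compound 3, `COc1ccc(Nn2c(SCC(=O)Nc3nc(-c4ccc(Cl)cc4)cs3)nc(C)c2C)cc1`, is not yet measured. It differs from compound 1 by methoxy in place of hydrogen on an aromatic carbon, para to a large group. For the measured compounds named here, no step between measured compounds that differ in a single place exists here, so no measured scale for this change is available. The expectation is a modest move toward weaker growth inhibition, somewhat beyond the scatter but not far. Compound 3 is expected to come in at 30000 nM, with a range from 8000 nM to 100000 nM. The step expected from compound 1 to compound 3 is a 2.6-fold higher number from compound 1 to compound 3 (0.41 log units; beyond the scatter).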

Compound 3, concentration for total growth inhibition: > 100000 nM
Compound 3: a limit, no number (the forecaster's own chance of this, stated with the estimate: 30%); middle value at least 3.3-fold (0.52 log units) away from the limit.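

In this assay, among the compounds shown here, methoxy in place of hydrogen on the anilino ring, para to a large group, gives the first single-place step, an at least 8.6-fold higher number from compound 1 to compound 3 (0.93 log units; beyond the scatter). This position therefore does not take the change without a loss of growth inhibition, which the earlier two-place comparison of compound 1 and compound 2 could not show. Compound 3 gives only a limit, > 100000 nM, so the step sets a minimum size for the loss and no true size, and the series still holds a single number, with most of its values now at the same ceiling: the limit of > 100000 nM in this assay, at which 2 of the 3 values shown sit.

Open, going by these compounds, is whether the loss belongs to methoxy in particular or to any replacement of hydrogen on this carbon, a question that fluorine or hydroxy at the same place would address. Also open, on these data alone, is whether a smaller group on the anilino ring keeps a measurable value, and how the same change reads on the shared core with a different group on the thiazole-linked aromatic ring.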